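Fluoro for Chloro on the Sulfonyl-Bearing Phenyl Ring

A few compounds are considered here, and "the series" means these few. Any claim that something is new, unique, unknown or untested is made for them only; others in the source may bear on it.

Three measured compounds share one core and differ only in single groups on two phenyl rings. Compound 1 `N#C/C(=C\c1ccccc1OS(=O)(=O)c1ccc(Cl)cc1)C(=O)Nc1nnc(Cc2ccc(Cl)cc2)s1` carries chloro on both of these rings, and in a functional assay on RS4-11 cells (Homo sapiens) for inhibition, read by CCK-8 assay, with a stated time of 48 h, tested at 20 uM (a lower number here means less inhibition of growth, a higher number more inhibition of growth at the concentration tested), compound 1 gives 64%. Compound 2 `N#C/C(=C\c1ccccc1OS(=O)(=O)c1ccc(F)cc1)C(=O)Nc1nnc(Cc2ccc(Cl)cc2)s1` differs from compound 1 by fluoro in place of chloro on an aromatic carbon; in this assay compound 2 gives 64%, so no change at the digits printed from compound 1 to compound 2 (within the scatter). Compound 3 `Cc1ccc(Cc2nnc(NC(=O)/C(C#N)=C/c3ccccc3OS(=O)(=O)c3ccc(Cl)cc3)s2)cc1` has methyl in place of chloro on the other ring; in this assay compound 3 gives 72%, and a number 8 percentage points higher from compound 1 to compound 3 (within the scatter). All three values lie within the usual scatter of one another, so none can be called more or less active than the others.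

Compound 4 `Cc1ccc(Cc2nnc(NC(=O)/C(C#N)=C/c3ccccc3OS(=O)(=O)c3ccc(F)cc3)s2)cc1` has not been measured. It differs from compound 3 by fluoro in place of chloro on an aromatic carbon. This is the same change as the one from compound 1 to compound 2, described identically in its place, and it occurs twice among the compounds shown. The two cores on which it is made differ by methyl in place of chloro on an aromatic carbon.

The expected step is a number 1 percentage points lower from compound 3 to compound 4 (within the scatter), because no change at the digits printed from compound 1 to compound 2 (within the scatter). Compound 4 is therefore estimated to give 71% in this assay, with the range running from 58% to 82%.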

Compound 4, percent growth inhibition at one concentration: 73%
For compound 4 the middle estimate is 2 percentage points below the measured one; the range from low to high includes it.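

Going from 4-chlorophenyl to 4-fluorophenyl on the core of compound 3 gives a number 1 percentage points higher from compound 3 to compound 4 (within the scatter) in this assay, and the same change on the core of compound 1 reads alike: the same change on two cores in this assay, no change at the digits printed (within the scatter) from compound 1 to compound 2 and a number 1 percentage points higher (within the scatter) from compound 3 to compound 4, 1 percentage points apart, within the scatter of two such steps. The second change, methyl in place of chloro on the other ring, gives a number 9 percentage points higher from compound 2 to compound 4 (within the scatter) with fluoro already in place, and it too reads alike on its two cores: the same change on two cores in this assay, a number 8 percentage points higher (within the scatter) from compound 1 to compound 3 and a number 9 percentage points higher (within the scatter) from compound 2 to compound 4, 1 percentage points apart, within the scatter of two such steps. Across these four compounds, then, neither change reads differently on one core than on the other, but every step lies within the scatter, so this shows only that no effect could be detected on either core, not that a real effect carries over, and it rests on just two cores at one tested concentration.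

On these data alone, only chloro, fluoro and methyl appear at these two places, so it remains open whether a more different group, such as an amine, a carboxylic acid or a longer chain, would move the number beyond the scatter. As far as these compounds go, it also remains open whether such a step would then carry from one core to the other as these do, or whether compounds that read alike here would still read alike at other concentrations.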